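Methoxy Additions on Two Rings of a Shared Scaffold

A few compounds are considered here, and "the series" means these few. Any claim that something is new, unique, unknown or untested is made for them only; others in the source may bear on it.

Of the compounds shown here, three have been tested in a functional assay on MIA PaCa-2 cells (Homo sapiens) for antiproliferative activity, read by sulforhodamine B assay, with a stated time of 48 h; a lower number here means a stronger inhibitor, a higher number a weaker inhibitor. Compound 1 `COc1cc(OC)c2sc(-c3ccc(N/C=C\C(=O)c4ccc(OC)c([N+](=O)[O-])c4)c(C)c3)nc2c1` gives 13900 nM. Compound 2 `COc1cc(OC)c2sc(-c3ccc(N/C=C\C(=O)c4ccc(OC)c(O)c4)cc3)nc2c1` gives 11600 nM, and compound 3 `COc1ccc(C(=O)/C=C\Nc2ccc(-c3nc4cc(OC)c(OC)c(OC)c4s3)cc2)cc1O` gives 32800 nM. Compound 3 differs from compound 2 by methoxy in place of hydrogen on an aromatic carbon, and this produced a 2.8-fold higher number from compound 2 to compound 3 (0.45 log units; beyond the scatter). Compound 1 and compound 2 differ in more than one place, so the difference between the two cores is not broken down here; their values lie within the scatter of each other.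

Compound 4 `COc1cc(OC)c2sc(-c3ccc(N/C=C\C(=O)c4cc(OC)c(OC)c([N+](=O)[O-])c4)c(C)c3)nc2c1` has not yet been measured. It differs from compound 1 by methoxy in place of hydrogen on an aromatic carbon. This is the same kind of change as that from compound 2 to compound 3, but not the same: there the entering group sat on a ring that is part of a fused system, ortho to two methoxy groups, meta to a fused ring and para to a fused ring, whereas here it sits ortho to one methoxy group, meta to a large group and meta to a nitro group. Resting on a 2.8-fold higher number from compound 2 to compound 3 (0.45 log units; beyond the scatter), a similar step of a 1.8-fold higher number from compound 1 to compound 4 (0.25 log units; within the scatter) is expected for compound 4, with broad uncertainty. Compound 4 is therefore estimated at 25000 nM in this assay, between 9000 nM and 65000 nM.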

Compound 4, half-maximal inhibitory concentration: 10400 nM
Beside the measured number, compound 4's estimate is 2.4-fold (0.38 log units) above it, and the stated range covers the measured number.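

In this assay, methoxy in place of hydrogen on an aromatic carbon gave a 1.3-fold lower number from compound 1 to compound 4 (0.13 log units; within the scatter), so compound 4 cannot be told apart from compound 1 in this assay. The same kind of change therefore did not carry over with the same result from one core to the other: the same change on two cores in this assay, a 2.8-fold higher number (0.45 log units; beyond the scatter) from compound 2 to compound 3 and a 1.3-fold lower number (0.13 log units; within the scatter) from compound 1 to compound 4, 3.8-fold (0.58 log units) apart, beyond the scatter of two such steps. This rests on a single pair for each core, with the entering group at a different place in each pair, so it does not show whether the core, the place or both set the outcome, and it gives no rule for the series.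

The compounds shown leave open whether the methoxy change, made at the same place on both cores, would give matching steps. They also leave open whether an ethoxy group or a fluorine in place of the same hydrogen would follow either of the two steps seen with methoxy.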